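Series notes: methyl to chloro swap on the core

This account rests on a few compounds, and the source may have more. Where it says the series, first, only, none or still open, it means among the compounds named here.

Measured so far:
Compound 1 `Cc1ccc2occ(C3N=C(c4ccccc4)SS3)c(=O)c2c1` gives > 100000 nM in a functional assay on HEp-2 cells (Homo sapiens) for inhibition, read by sulforhodamine B assay, with a stated time of 48 h (a lower number here means a stronger inhibitor, a higher number a weaker inhibitor), a limit only.
Compound 2 `O=c1c(C(=S)Nc2ccccc2)coc2cc(Cl)ccc12` gives > 100000 nM in this assay, again a limit only.

For the measured compounds named here, compound 1 therefore stands at the limit of > 100000 nM in this assay, at which 2 of the 2 values shown sit; no numerical potency is known for it, and the same holds for compound 2, so no measured step exists in the set.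

Compound 3 `O=c1c(C2N=C(c3ccccc3)SS2)coc2ccc(Cl)cc12` is the next candidate. It differs from compound 1 by chloro in place of methyl on an aromatic carbon. Going by the values given here, with no measured step to lean on, no change beyond the scatter is expected in this assay, and another limit is the likelier outcome. Compound 3 is expected near 150000 nM, with a range of 50000 nM to 500000 nM. The expected step that the limit leaves unreadable from compound 1 to compound 3 is judged to lie within the scatter.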

Compound 3, half-maximal inhibitory concentration: 74900 nM
Compound 3: the middle estimate sits 2.0-fold (0.30 log units) above what was measured; the measured number falls inside the stated range.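

Chloro in place of methyl on an aromatic carbon of the shared core brings the first numerical reading in this assay, where compound 3 gives 74900 nM. The change amounts to an at least 1.3-fold lower number from compound 1 to compound 3 (0.12 log units; that floor lies within the scatter), so only a floor is known, and the full size of the step may or may not exceed the scatter. The step has no upper bound because compound 1 has a limit and no number: the limit of > 100000 nM in this assay, at which 2 of the 3 values shown sit.

The compounds shown leave open how bromo, an amine or a methoxy group on this aromatic carbon would read. They also leave open whether a longer chain there would give a number or another limit.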